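The source may hold more compounds than are shown below. What is called first, only, known or untested is meant among the compounds shown, and "the series" means these compounds.

Working notes on the series. Among the compounds with values here, in a functional assay for antagonist activity at cysteinyl leukotriene receptor 1 (Cavia porcellus) (a lower number here means a less potent compound, a higher number a more potent compound, by a factor of ten per unit of this negative logarithm), compound 3 `O=C(O)CCCCn1nnc(-c2ccc(OCCCCc3ccccc3)cc2)n1` gives 5.97, the highest of the three numbers measured so far. Within the data shown here, compound 1 `FC(F)(F)CCCCCCCOc1ccc(-c2nnn(CCCCc3nnn[nH]3)n2)cc1` gives 5.43 and compound 2 `CCCCCCCCCCOc1ccc(-c2nnn(CCCCc3nnn[nH]3)n2)cc1` gives 5.09; the one step measured, a number 0.34 log units lower from compound 1 to compound 2 (beyond the scatter), concerns the chain end and says nothing about the acid end. Compound 4 `NC(=O)CCCCn1nnc(-c2ccc(OCCCCc3ccccc3)cc2)n1` differs from compound 3 by amino in place of hydroxy on a carbonyl carbon, carboxy to carbamoyl. Among the measured compounds shown here, no measured step bears on this change, and no analogue without an acidic group is on hand, so any expectation rests on the change alone. Compound 4 is expected to lose some potency, an estimated step of a number 0.57 log units lower from compound 3 to compound 4 (beyond the scatter) in this assay, to an estimated 5.4 with a range of 4.7 to 6.1.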

Compound 4, negative logarithm of the antagonist equilibrium constant: 5.41
For compound 4 the middle estimate is 0.01 log units below the measured one, and the stated range covers the measured number.
By their numbers in this assay, from the lowest: compound 2; then compounds 4 and 1 (each within the scatter of the next); then compound 3.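

Within the data shown here, this is the first step measured at the acid end of the series: in this assay, carbamoyl in place of carboxy gives a number 0.56 log units lower from compound 3 to compound 4 (beyond the scatter), so the group on this carbonyl carbon bears on the number. The leaving hydroxy and the entering amino have the same heavy-atom and hydrogen-bond donor counts, so those counts do not separate the pair. Nothing on hand explains the step. As far as these compounds go, whether a methyl ester or a hydroxamic acid on this carbonyl carbon would fall nearer compound 3 or compound 4 remains open. Also open, from the compounds shown here alone, is whether the step holds with a longer chain carrying the carbonyl carbon.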